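The source may report more compounds than this note shows. Statements on the series, on what has been measured and on what is new or still open speak of the compounds shown alone.

Compound 1, `CC1(C)N=C(N)N=C(N)N1c1ccc(OCCCNC(=O)Nc2ccc(S(=O)(=O)F)cc2)c(Cl)c1`, was examined in an assay on isolated protein for inhibition of Dihydrofolate reductase (Mus musculus) (on this read-out lower numbers stand for lower potency and higher numbers for higher potency (the scale is a negative logarithm)), where compound 1 gives 7.68. In this assay compound 3, `CC1(C)N=C(N)N=C(N)N1c1ccc(OCc2ccc(S(=O)(=O)F)cc2)c(Cl)c1`, gives 7.58, and the two values lie within the scatter of each other. The difference between the core of compound 1 and the core of compound 3 is not broken down here. Compound 2, `Cc1cc(S(=O)(=O)F)ccc1COc1ccc(N2C(N)=NC(N)=NC2(C)C)cc1Cl`, gives 7.38 in this assay; the step of a number 0.20 log units lower from compound 3 to compound 2 (within the scatter) comes from methyl in place of hydrogen on an aromatic carbon.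

Compound 4, `Cc1cc(NC(=O)NCCCOc2ccc(N3C(N)=NC(N)=NC3(C)C)cc2Cl)ccc1S(=O)(=O)F`, has not yet been measured. It arises from compound 1 by methyl in place of hydrogen on an aromatic carbon. This is the same kind of change as that from compound 3 to compound 2, but not the same: there the methyl sits ortho to a large group and meta to a fluorosulfonyl group, whereas in compound 4 it sits ortho to a fluorosulfonyl group and meta to a large group.

The account expects a step of a number 0.20 log units lower from compound 1 to compound 4 (within the scatter) in this assay, resting on the measured step of a number 0.20 log units lower from compound 3 to compound 2 (within the scatter) seen for compound 3 and compound 2. On that basis compound 4 is estimated to give 7.48, with an expected range from 7.05 to 7.9.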

Compound 4, logarithm of the reciprocal of the active concentration, log(1/C): 8.06
The estimate for compound 4 lay 0.58 log units below the measured number; measured number outside the range, above it.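

In this assay, methyl in place of hydrogen on an aromatic carbon gives a number 0.38 log units higher from compound 1 to compound 4 (beyond the scatter). Set beside the earlier step, this shows that the change does not carry over between these two cores as a fixed increment: the same change on two cores in this assay, a number 0.20 log units lower (within the scatter) from compound 3 to compound 2 and a number 0.38 log units higher (beyond the scatter) from compound 1 to compound 4, 0.58 log units apart, beyond the scatter of two such steps It does not show what sets the two steps apart, since the two pairs differ in the core and also in where the methyl sits, ortho to a fluorosulfonyl group in compound 4, and a single pair on each core cannot separate these two differences.

The compounds shown leave open whether a methyl ortho to a fluorosulfonyl group on the core of compound 3 would follow the step seen on the core of compound 1, and whether a methyl in the other place would do so on the core of compound 1. They also leave open how an ethyl group or a chlorine atom in place of the methyl would behave on either core.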